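Shortening the Chain on the Shared Core

The source may report more compounds than this note shows. Statements on the series, on what has been measured and on what is new or still open speak of the compounds shown alone.

In a functional assay on K562 cells (Homo sapiens) for antiproliferative activity, read by CellTiter-Glo, with a stated time of 72 h (on this read-out higher numbers stand for an effect only at larger amounts of compound and lower numbers for an effect already at smaller amounts), compound 1 `CCC(C)Nc1ncnc2c1ncn2[C@@H]1O[C@H](COS(N)(=O)=O)[C@@H](O)[C@H]1O` gives > 1000 nM, which is a limit of the assay and not a number. Among the compounds with values here, compound 2 `CCCCCC(C)Nc1ncnc2c1ncn2[C@@H]1O[C@H](COS(N)(=O)=O)[C@@H](O)[C@H]1O` gives 203 nM, the only actual number so far. Within the data shown here, the one measured step is an at least 4.9-fold lower number from compound 1 to compound 2 (0.69 log units; beyond the scatter), and it also concerns the chain carried on the nitrogen.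

Compound 3 `COCCNc1ncnc2c1ncn2[C@@H]1O[C@H](COS(N)(=O)=O)[C@@H](O)[C@H]1O` keeps the core of compound 2 and changes that chain: 2-methoxyethyl in place of 1-methylhexyl on a nitrogen on an aromatic ring. This puts 2-methoxyethyl in place of 1-methylhexyl on a nitrogen on an aromatic ring. Among the measured compounds shown here, the entering group is the smaller one, and it brings an oxygen and a hydrogen-bond acceptor, which the single measured step does not test. That step therefore serves only as a rough guide, run in reverse. An estimated step of a 6.4-fold higher number from compound 2 to compound 3 (0.81 log units; beyond the scatter) is expected in this assay, towards a higher number and of about the measured size. The result may well be reported only as a limit. For compound 3 the expected value is about 1300 nM, with an estimated range of 350 nM to 5000 nM.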

Compound 3, half-maximal effective concentration: > 1000 nM
Compound 3 gave a limit, no number (the forecaster's own chance of this, stated with the estimate: 60%); the middle value is on the limit's open side.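

In this assay, 2-methoxyethyl in place of 1-methylhexyl on the nitrogen gives an at least 4.9-fold higher number from compound 2 to compound 3 (0.69 log units; beyond the scatter). This shows that the number reached with 1-methylhexyl is not kept when a shorter chain carrying an oxygen enters at this position, and the printed size is only a lower bound on the true step. Compound 2 remains the only compound with a number, and the step from compound 1 to compound 3 cannot be read, so sec-butyl and 2-methoxyethyl cannot be ordered, and the picture at this position is capped: the limit of > 1000 nM in this assay, at which 2 of the 3 values shown sit.

The change from 1-methylhexyl to 2-methoxyethyl alters both the size of the chain and its make-up, so the compounds shown do not tell whether the loss goes with the shorter chain or with the oxygen; an all-carbon chain such as n-butyl or n-pentyl on the same nitrogen would bear on that. From the compounds shown here alone, it also stays open whether a chain longer than 1-methylhexyl, or one ending in an amine, would give a lower number than compound 2 does.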